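Methyl for hydrogen on a phenolic oxygen: expected effect

This account rests on a few compounds, and the source may have more. Where it says the series, first, only, none or still open, it means among the compounds named here.

Measured compounds:
compound 1 `COc1ccc(/C=N/Cc2cccnc2)cc1O` gives 30 mg/kg in a functional assay on the whole organism (strain Swiss albino) with Mus musculus as the target, in the maximal electroshock model, with a stated time of 0.5 h; on this read-out lower numbers stand for an effect already at smaller amounts and higher numbers for an effect only at larger amounts of compound
compound 2 `Clc1ccccc1/C=N/Cc1cccnc1` gives 30 mg/kg
compound 3 `C(=C/c1ccccc1)\C=N\Cc1cccnc1` gives 30 mg/kg

All three compounds were tested in this assay, and compound 1 sits level with compound 2 and compound 3 at the digits shown: the values of compound 1 and compound 2 lie within the scatter of each other, as do those of compound 1 and compound 3. The three measured values therefore give no sign that the varied part of the molecule shifts the read-out at all.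

Compound 4 `COc1ccc(/C=N/Cc2cccnc2)cc1OC` has not been measured. It differs from compound 1 in one place (methyl in place of hydrogen on an oxygen on an aromatic ring). For the measured compounds named here, no pair of measured compounds differs in a single place, so no measured step can be used as a guide. Given that compound 1 gives 30 mg/kg while compound 2 and compound 3 give the same figure, the change from compound 1 to compound 4 is expected to produce no step beyond the scatter. Compound 4 is thus expected to give about 40 mg/kg, within a range of 20 mg/kg to 100 mg/kg, which means an expected step of a 1.3-fold higher number from compound 1 to compound 4 (0.12 log units; within the scatter).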

Compound 4, minimum effective dose: 300 mg/kg
For compound 4 the middle estimate is 7.5-fold (0.88 log units) below the measured one; measured number outside the range, above it.
By their numbers in this assay, from the lowest: compounds 1, 2 and 3 (each within the scatter of the next); then compound 4.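

In this assay, for the compounds shown here, replacing the hydrogen on this oxygen with methyl gives a 10-fold higher number from compound 1 to compound 4 (1.00 log units; beyond the scatter), which is the first single-place change that can be read, and it lies beyond the scatter. This oxygen on an aromatic ring is therefore a sensitive spot: going from hydroxy to methoxy adds only one carbon, yet a larger dose is then needed for an effect. Nothing measured here says why this small change has so clear an effect on the read-out.

Only hydrogen and methyl are shown on this oxygen, so it remains open whether an ethyl group or a longer chain would raise the number further. As far as these compounds go, it is also open how an amine in place of the hydroxy group would compare with compound 1.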